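Cyclopropyl in place of aromatic hydrogen on compound 1

The source may report more compounds than this note shows. Statements on the series, on what has been measured and on what is new or still open speak of the compounds shown alone.

Measured so far:
compound 1 `OC(Cc1ccccc1)c1cccc2[nH]ncc12` 14%
compound 2 `Cc1cc(C(O)Cc2ccccc2)c2cn[nH]c2c1` 18%

Within the data shown here, in an assay for inhibition of Indoleamine 2,3-dioxygenase 1 variant C129Y (Homo sapiens), read by spectrophotometry, with a stated time of 30 min, tested at 10 uM (on this read-out higher numbers stand for more inhibition at the one concentration tested (going by the name of the read-out) and lower numbers for less inhibition), compound 1 gives 14% and compound 2 gives 18%; the step of a number 4 percentage points higher from compound 1 to compound 2 (within the scatter) is within the scatter, so compound 1 stands level with the only other measured number. Compound 3 `OC(Cc1ccccc1)c1cc(C2CC2)cc2[nH]ncc12` differs from compound 1 by cyclopropyl in place of hydrogen on an aromatic carbon. Among the measured compounds shown here, the one step that bears on this, methyl in place of hydrogen on an aromatic carbon, was a number 4 percentage points higher from compound 1 to compound 2 (within the scatter); a change of similar kind is therefore expected to give no step beyond the scatter, estimated as a number 6 percentage points higher from compound 1 to compound 3 (within the scatter). Compound 3 is estimated at 20%, from 8% to 34%.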

Compound 3, a percentage reported as inhibition, at one concentration (the size of the read-out at that concentration, not a potency): 20%
Compound 3: the middle estimate sits on the measured number at the digits printed, within the range that was stated.
By their numbers in this assay, from the lowest: compounds 1, 2 and 3 (each within the scatter of the next).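

In this assay, cyclopropyl on this aromatic carbon gives a number 6 percentage points higher from compound 1 to compound 3 (within the scatter), and cyclopropyl in place of methyl gives a number 2 percentage points higher from compound 2 to compound 3 (within the scatter). The position therefore carries a three-membered carbon ring as well as a methyl, and neither change gives a step beyond the scatter. No measurement at hand offers an explanation for this flat result.

Still open, from the compounds shown here alone, is whether an amine, a carboxylic acid or a longer chain at this position would give a step beyond the scatter. The compounds shown also leave open whether any substituent here separates from hydrogen.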